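A few compounds are considered here, and "the series" means these few. Any claim that something is new, unique, unknown or untested is made for them only; others in the source may bear on it.

Working notes on a carbamate series carrying a selenocyanate.

Three compounds have numbers in an ADME assay on 184B5 cells (Homo sapiens) for cytotoxicity, read by MTT assay, with a stated time of 72 h; on this read-out higher numbers stand for weaker inhibition of growth and lower numbers for stronger inhibition of growth. Compound 1 `C=CCOC(=O)Nc1ccc([Se]C#N)cc1` gives 9800 nM in this assay, the lowest of the three numbers. Compound 2 `N#C[Se]c1ccc(NC(=O)OCc2ccc([N+](=O)[O-])cc2)cc1` gives 18000 nM, within the scatter of compound 1. Compound 3 `CCCCOC(=O)Nc1ccc([Se][Se]c2ccc(NC(=O)OCCCC)cc2)cc1`, the diselenide, gives 26000 nM, beyond the scatter of compound 1.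

Compound 4 `N#C[Se]c1ccc(NC(=O)Oc2ccccc2)cc1` differs from compound 1 in one place: phenyl in place of allyl on an oxygen next to a carbonyl group. For the measured compounds named here, no measured pair in this assay shows such a change. Across the three compounds, swapping the ester side of the carbamate has moved the numbers little. For compound 4 the step of a 1.2-fold higher number from compound 1 to compound 4 (0.09 log units; within the scatter) is therefore expected to be small, not clearly beyond the scatter. Compound 4 is expected at about 12000 nM, within a range from 5000 nM to 30000 nM.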

Compound 4, concentration for total growth inhibition: 22700 nM
Estimate against measurement, compound 4: 1.9-fold (0.28 log units) below; low and high end bracket the measured number.
By their numbers in this assay, from the lowest: compounds 1, 2, 4 and 3 (each within the scatter of the next, the first and the last beyond it).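

In this assay, for the compounds shown here, phenyl in place of allyl on an oxygen next to a carbonyl group gives a 2.3-fold higher number from compound 1 to compound 4 (0.36 log units; beyond the scatter) as the first single-place step. This position is therefore not silent: a change on this side of the carbamate can carry the number beyond the scatter, though the step is modest. No measurement shown accounts for this step.

From the compounds shown here alone, it remains open whether a propyl group, keeping the chain of allyl without its double bond, or a benzyl group on the same oxygen would stay with allyl or with phenyl.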